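Trimming the Amine Substituent to a Short Chain

This account rests on a few compounds, and the source may have more. Where it says the series, first, only, none or still open, it means among the compounds named here.

This account follows a small series built on one shared core, tested in a functional assay on CCRF-CEM cells for agonist activity at C-X-C chemokine receptor type 4 (Homo sapiens), read by calcium flux, with a stated time of 25 min; a lower number here means that less compound is needed, a higher number that more compound is needed for the effect. Compound 1 `CC(C)N1CCN(c2cccc3c2C[C@H](CN(C)[C@H]2CCCc4cccnc42)NC3)CC1` reaches only a limit of the assay, > 30000 nM. Compound 3 `CN(C[C@H]1Cc2c(cccc2N2CCN(c3cccc(C(F)(F)F)c3)CC2)CN1)[C@H]1CCCc2cccnc21` likewise stops at a limit in this assay, > 30000 nM. The step that the two limits leave unreadable from compound 1 to compound 3 therefore cannot be read, because both ends rest at the limit of > 30000 nM in this assay, at which 3 of the 3 values shown sit. Compound 2 `FC1(F)CCC(CN(C[C@H]2Cc3c(cccc3N3CCNCC3)CN2)[C@H]2CCCc3cccnc32)CC1` stands at a limit as well, giving > 30000 nM in this assay, so its place on the numbers is a boundary rather than a value.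

Compound 4 `CCCN(C[C@H]1Cc2c(cccc2N2CCNCC2)CN1)[C@H]1CCCc2cccnc21` differs from compound 2 by ethyl in place of 4,4-difluorocyclohexyl on a saturated chain carbon bound to an amine nitrogen. No measured step touches this change: the single step shown, from compound 1 to compound 3, concerns a different position and is unreadable in any case. For the measured compounds named here, the three values so far offer no direction, only the limit they share. On that basis compound 4 is expected to remain at the same limit, and the estimated step of a number no higher from compound 2 to compound 4 (the limit leaves the size open) is taken to be none beyond the scatter. Compound 4 is thus estimated at 30000 nM in this assay, within a range from 8000 nM to 100000 nM, with the likeliest outcome being another limit rather than a number.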

Compound 4, half-maximal effective concentration: > 30000 nM
Compound 4: a limit, no number; the forecaster's own chance of this, stated with the estimate: 80%; the middle value sits exactly at the limit.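

In this assay compound 4 gives > 30000 nM, which is a limit and not a number. The step from compound 2 to compound 4 cannot be read, because both compounds rest at a limit: the limit of > 30000 nM in this assay, at which 4 of the 4 values shown sit. The compounds shown leave open which substituents on the shared core, if any, would give a numerical value in this assay.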